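Swapping a Thiophene for an Imidazole: Expected Effect on Cell Growth

The source may hold more compounds than are shown below. What is called first, only, known or untested is meant among the compounds shown, and "the series" means these compounds.

Measured compounds:
- compound 1, `N#Cc1ccc(N2CCc3cc(-c4cncnc4)ccc32)cc1C(F)(F)F`: "not determined" (no result reported)
- compound 2, `N#Cc1ccc(N2CCCc3c(-c4cccnc4)cccc32)cc1C(F)(F)F`: 10500 nM
- compound 3, `CCN(c1ccc(C#N)c(Cl)c1)c1cc(-c2cccs2)ccc1C`: "not determined" (no result reported)

The measurement in question is an ADME assay on L02 cells (Homo sapiens) for antiproliferative activity, read by CCK-8 assay, with a stated time of 6 days; a higher number here means a weaker inhibitor, a lower number a stronger inhibitor. Of the three compounds with results, only compound 2 carries a number, giving 10500 nM, a weak effect on the growth of these cells. Compound 3 stands without a single number; one further compound, compound 1, likewise has no single number. Going by the values given here, no pair of measured compounds differs in a single place, so no step size can be read from the data.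

The new compound is compound 4, `CCN(c1ccc(C#N)c(Cl)c1)c1cc(-n2ccnc2)ccc1C`. It differs from compound 3 in one place: 1H-imidazol-1-yl in place of thiophen-2-yl on an aromatic carbon. Among the compounds with values here, with no step between measured compounds to lean on, the direction and size of the change in this assay cannot be inferred from the data; the expectation is simply that compound 4, like compound 2, lands in the weakly inhibiting region, with a fair chance the result comes back only as a limit. The estimate for compound 4 is 12000 nM, expected to lie between 3500 nM and 40000 nM.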

Compound 4, half-maximal inhibitory concentration: 15000 nM
Beside the measured number, compound 4's estimate is 1.3-fold (0.10 log units) below it; low and high end bracket the measured number.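

Going by these compounds alone, compound 3 has no single number in this assay and so no step from it to compound 4 can be read. What replacing thiophen-2-yl with 1H-imidazol-1-yl does to this reading stays open, and no other evidence shown bears on the result for compound 4.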